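Bromo to Hydrogen on a Fused Core: Expected Half-life

This account rests on a few compounds, and the source may have more. Where it says the series, first, only, none or still open, it means among the compounds named here.

Compound 1 `CCCNC(=O)C1CCN(C(=O)c2cc3nc(Br)sc3n2Cc2ccc(OC)cc2)CC1`: 0.368 h
Compound 2 `CCCNC(=O)[C@@H]1C[C@H]2CCC[C@@H](C1)[C@@H]2NC(=O)c1cc2sc(-c3ccccc3)nc2n1Cc1ccc(OC)cc1`: 0.453 h
Compound 3 `CCCNC(=O)C1CC12CCN(C(=O)c1cc3sc(-c4ccccc4)nc3n1Cc1ccc(OC)cc1)CC2`: 0.697 h

Of the compounds shown here, three that share a core have been measured in an ADME assay on microsomes from liver (Homo sapiens) for metabolic stability; on this read-out lower numbers stand for a shorter-lived compound and higher numbers for a longer-lived compound. Compound 1 gives 0.368 h, compound 2 gives 0.453 h, and compound 3 gives 0.697 h. Compound 1 gives the smallest of the three numbers, but neither of the other two lies beyond the usual scatter of repeated measurements from it; the numbers of compound 2 and compound 3 are close to that of compound 1 and no order among the three can be read from them.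

Compound 4 `CCCNC(=O)C1CCN(C(=O)c2cc3ncsc3n2Cc2ccc(OC)cc2)CC1` has not yet been measured in this assay. It differs from compound 1 in one place: hydrogen in place of bromo on an aromatic carbon. For the measured compounds named here, no measured pair in this set shows the same change, so nothing in the data tells how large a step this change makes in this assay. The expectation is therefore a step that stays within the scatter, with no clear direction, and a number for compound 4 close to that of compound 1.

Compound 4 is expected to give 0.35 h in this assay, within a range from 0.15 h to 0.8 h. The step this estimate means is a 1.1-fold lower number from compound 1 to compound 4 (0.02 log units; within the scatter), which is expected to be no more than the scatter.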

Compound 4, half-life: 0.543 h
Compound 4: the middle estimate sits 1.6-fold (0.19 log units) below what was measured; the measured number falls inside the stated range.
By their numbers in this assay, from the lowest: compounds 1, 2, 4 and 3 (each within the scatter of the next).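

In this assay, for the compounds shown here, the exchange of bromo for hydrogen on the aromatic carbon, next to the ring nitrogen and next to the ring sulfur, gives the only single-place step in this small set (a 1.5-fold higher number from compound 1 to compound 4 (0.17 log units; within the scatter)). Going by these compounds alone, it shows that this position can lose its one heavy atom, a bromine, without a step beyond the scatter, something the earlier compounds could not show, as they differ from one another in more than one place. No measurement at hand bears on what lies behind this step.

Going by these compounds, what other groups would do in this place stays open: an amine, a carboxylic acid or a methoxy group might give a step of another size, and the data offer no way to tell. On these data alone, compound 2 and compound 3 carry a phenyl group on their cores but also differ from compound 1 in other places, so it also remains open whether the same exchange would give a similar step with their amide parts.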